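Chain extension at the saturated carbon bound to aromatic nitrogen

The source may hold more compounds than are shown below. What is called first, only, known or untested is meant among the compounds shown, and "the series" means these compounds.

Going by the values given here, compound 1 `Cn1c(Cc2nn(C)c(=O)c3ccccc23)nnc1SCCCCCCCC(=O)Nc1ccc(Cl)cc1Cl` gives the lower of the two numbers so far in an assay on NK92 cells for inhibition of interleukin-2 (Homo sapiens), read by AlphaScreen, with stated times of 30 min and 1 h (a lower number here means a stronger inhibitor, a higher number a weaker inhibitor), at 350 nM; compound 2 `Cn1nc(Cc2nnc(SCCCCCCCC(=O)Nc3ccc(Cl)cc3Cl)n2CCC=O)c2ccccc2c1=O` gives 960 nM. Among the compounds with values here, the one measured step, a 2.7-fold higher number from compound 1 to compound 2 (0.44 log units; beyond the scatter), adds a chain at the same place as the change now considered. Compound 3 `CN(C)CCCn1nc(Cc2nnc(SCCCCCCCC(=O)Nc3ccc(Cl)cc3Cl)n2C)c2ccccc2c1=O` differs from compound 1 by 2-(dimethylamino)ethyl in place of hydrogen on a saturated chain carbon bound to an aromatic nitrogen. Since the earlier addition at this place weakened inhibition beyond the scatter, a weakening of similar size is expected for compound 3 in this assay, a 2.1-fold higher number from compound 1 to compound 3 (0.33 log units; beyond the scatter). Compound 3 is therefore estimated at 750 nM, with a range of 300 nM to 1900 nM.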

Compound 3, half-maximal inhibitory concentration: > 30000 nM
Compound 3: no number, only a limit; the forecaster's own chance of this, stated with the estimate: 3%; middle value at least 40-fold (1.60 log units) from the limit.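

In this assay, the change at this saturated chain carbon bound to an aromatic nitrogen is not always modest: 2-(dimethylamino)ethyl gives an at least 85-fold higher number from compound 1 to compound 3 (1.93 log units; beyond the scatter), far larger than a 2.7-fold higher number from compound 1 to compound 2 (0.44 log units; beyond the scatter) with formylmethyl. For compound 3 the result is a limit and not a number: the limit of > 30000 nM in this assay, at which 1 of the 3 values shown sits. Across these two changes, the size of the step differs sharply with the group that enters.

From the compounds shown here alone, how much of the loss belongs to the dimethylamino group and how much to the chain length remains open. A hydroxyl or a carboxylic acid at the end of a similar chain would bear on that question.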